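Hydroxyaryl hydrazones versus a chlorophenyl hydrazone on a shared core

The compounds below may be only part of what the source reports. "The series", "measured", "known", "first", "only" and "open" are said of these compounds alone.

Three hydrazones built on one shared core were tested in a functional assay on MCF7 cells (Homo sapiens) for antiproliferative activity, read by MTT assay, with a stated time of 72 h; on this read-out lower numbers stand for stronger inhibition and higher numbers for weaker inhibition. Compound 1 `CCCSc1nc(N/N=C(\C)c2ccc(O)cc2)c2nnn(Cc3ccccc3)c2n1` gives 21600 nM in this assay. Compound 3 `CCCSc1nc(N/N=C(\C)c2ccccc2O)c2nnn(Cc3ccccc3)c2n1` gives 11000 nM in this assay. For compound 2 `CCCSc1nc(N/N=C/c2cccc(Cl)c2)c2nnn(Cc3ccccc3)c2n1` this assay reports only a limit, > 64000 nM, so compound 2 stands at the weak end of what has been measured. Its two steps to the hydroxyaryl compounds bear on the next change: an at least 2.9-fold higher number from compound 1 to compound 2 (0.47 log units; beyond the scatter), and an at least 5.8-fold lower number from compound 2 to compound 3 (0.76 log units; beyond the scatter), while a 2.0-fold lower number from compound 1 to compound 3 (0.29 log units; within the scatter).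

Compound 4 `CCCSc1nc(N/N=C/c2c(O)ccc3ccccc23)c2nnn(Cc3ccccc3)c2n1` differs from compound 2 by 2-hydroxynaphthalen-1-yl in place of 3-chlorophenyl on a carbon with a double bond to nitrogen. Like compound 3, compound 4 carries a hydroxyl on the aryl that hangs from the hydrazone carbon, but it lacks the methyl on that carbon that compounds 1 and 3 both have, so the comparison is not exact. Compound 4 is nonetheless expected to return a number rather than a limit, in the range of compounds 1 and 3, with an at least 4.2-fold lower number from compound 2 to compound 4 (0.63 log units; beyond the scatter) expected. The estimate for compound 4 in this assay is 15000 nM, from 5000 nM to 60000 nM.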

Compound 4, half-maximal inhibitory concentration: 6400 nM
Beside the measured number, compound 4's estimate is 2.3-fold (0.37 log units) above it; the range from low to high includes it.
By their numbers in this assay, from the lowest: compounds 4, 3 and 1 (each within the scatter of the next, the first and the last beyond it). At a limit, above all of these: compound 2.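

In this assay, 2-hydroxynaphthalen-1-yl in place of 3-chlorophenyl on a carbon with a double bond to nitrogen gives an at least 10-fold lower number from compound 2 to compound 4 (1.00 log units; beyond the scatter). The earlier steps shown here from compound 2 changed the aryl and added a methyl on that carbon together, whereas here only the aryl changes, so the methyl is not needed for a measured value in place of a limit. The size of this step remains a bound, since one end of it is a limit and not a number: the limit of > 64000 nM in this assay, at which 1 of the 4 values shown sits.

The hydroxyl and the second aromatic ring enter together, so the compounds shown do not separate their contributions; a plain naphthalen-1-yl or a methoxy in place of the hydroxyl would bear on this. Going by these compounds, how an amine or a carboxylic acid at that place would read in this assay also stays open.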